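The source may hold more compounds than are shown below. What is called first, only, known or untested is meant among the compounds shown, and "the series" means these compounds.

Measured so far in an ADME assay on Huh-7 cells (Homo sapiens) for cytotoxicity, read by XTT assay, with a stated time of 2 days; a lower number here means that less compound is tolerated, a higher number that more compound is tolerated:
compound 1, `O=c1[nH]cc(C#Cc2ccccc2)c(=O)[nH]1`: > 100 ug/mL
compound 2, `CCCc1ccc(C#Cc2c[nH]c(=O)[nH]c2=O)cc1`: > 100 ug/mL

The value of compound 1 is a limit of this assay, not a number. The value of compound 2 is likewise a limit of this assay. Compound 2 therefore stands at the top of what the assay reports, and both values shown sit there, as in the limit of > 100 ug/mL in this assay, at which 2 of the 2 values shown sit. For the measured compounds named here, the only measured step, a step that the two limits leave unreadable from compound 1 to compound 2, is unreadable between the two limits and gives no size.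

Compound 3, `CCCCCc1ccc(C#Cc2c[nH]c(=O)[nH]c2=O)cc1`, differs from compound 2 as follows: ethyl in place of hydrogen on a saturated chain carbon, three bonds along the chain from an aromatic carbon. Going by the values given here, no measured step bears on this change; the step from compound 1 to compound 2 is the nearest and is unreadable. The expectation for compound 3 is therefore that this assay again returns a limit, with an expected step of a number no higher from compound 2 to compound 3 (the limit leaves the size open). Compound 3 is estimated at 100 ug/mL, with a range from 50 ug/mL to 200 ug/mL.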

Compound 3, half-maximal cytotoxic concentration: > 100 ug/mL
Compound 3: only a limit was reported; the forecaster's own chance of this, stated with the estimate: 80%; the middle value sits exactly at the limit.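

No step can be read among compound 1, compound 2 and compound 3, since in this assay each returns only a limit: the limit of > 100 ug/mL in this assay, at which 3 of the 3 values shown sit.

The compounds shown leave open at what concentration any of them stops being tolerated, and whether propyl or pentyl in place of hydrogen changes that.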